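Amide variation on the shared core: estimate for compound 4

A few compounds are considered here, and "the series" means these few. Any claim that something is new, unique, unknown or untested is made for them only; others in the source may bear on it.

Measured in an assay on microsomes from liver for inhibition of 3-hydroxy-3-methylglutaryl-coenzyme A reductase (Rattus norvegicus); on this read-out higher numbers stand for weaker inhibition and lower numbers for stronger inhibition:
- compound 1, `Cc1ccc(CN(C)C(=O)c2nn(-c3ccc(F)cc3)c(OC[C@@H](O)C[C@@H](O)CC(=O)O)c2C(C)C)cc1`: 37 nM
- compound 2, `CC(C)c1c(C(=O)N2CCCC2c2ccccc2)nn(-c2ccc(F)cc2)c1OC[C@@H](O)C[C@@H](O)CC(=O)O`: 14 nM
- compound 3, `Cc1cccc(CNC(=O)c2nn(-c3ccc(F)cc3)c(OC[C@@H](O)C[C@@H](O)CC(=O)O)c2C(C)C)c1`: 4.9 nM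

Compound 3 stands lowest of the three; the steps of a 7.6-fold lower number from compound 1 to compound 3 (0.88 log units; beyond the scatter) and a 2.9-fold lower number from compound 2 to compound 3 (0.46 log units; beyond the scatter) both run toward it and lie beyond the scatter. Compound 4, `CC(C)c1c(C(=O)N2CCC[C@H](c3ccccc3)C2)nn(-c2ccc(F)cc2)c1OC[C@@H](O)C[C@@H](O)CC(=O)O`, differs from compound 3 by 3-phenylpiperidin-1-yl in place of (3-methylbenzyl)amino on a carbonyl carbon. Both measured steps concern the same carbonyl carbon. Compound 4 carries a ring-bound amine, as compound 2 does, so the reverse of a 2.9-fold lower number from compound 2 to compound 3 (0.46 log units; beyond the scatter) is the closest guide; a 2.6-fold lower number from compound 1 to compound 2 (0.42 log units; beyond the scatter) shows the two measured variants without the free amide hydrogen differ only modestly between themselves. A modest rise in this assay is therefore expected for compound 4, about a 2.4-fold higher number from compound 3 to compound 4 (0.39 log units; beyond the scatter). The estimate for compound 4 is 12 nM, range 4 nM to 40 nM.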

Compound 4, half-maximal inhibitory concentration: 4.8 nM
Compound 4: the middle estimate sits 2.5-fold (0.40 log units) above what was measured, and the stated range covers the measured number.
By their numbers in this assay, from the lowest: compounds 4 and 3 (each within the scatter of the next); then compound 2; then compound 1.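

In this assay, the step of a 1.0-fold lower number from compound 3 to compound 4 (0.01 log units; within the scatter) shows that this carbonyl carbon tolerates an amide without the amide hydrogen, which compounds 1 and 2 alone did not show. The step of a 2.9-fold lower number from compound 2 to compound 4 (0.46 log units; beyond the scatter) and the step of a 7.7-fold lower number from compound 1 to compound 4 (0.89 log units; beyond the scatter) show that losing that hydrogen does not settle the number: the group entering at this position does. Nothing available explains these steps. Open, going by these compounds, is how 4-phenylpiperidin-1-yl or morpholin-4-yl on this carbonyl carbon would read, and whether the opposite configuration of 3-phenylpiperidin-1-yl reads alike.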